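A few compounds are considered here, and "the series" means these few. Any claim that something is new, unique, unknown or untested is made for them only; others in the source may bear on it.

Measured in a functional assay on SK-OV-3 cells (Homo sapiens) for antiproliferative activity, read by MTT assay, with a stated time of 72 h; on this read-out higher numbers stand for weaker inhibition and lower numbers for stronger inhibition:
- compound 1 `C#Cc1cccc(NC(=O)CCc2cccc3c2B(O)OC3)c1`: 980 nM
- compound 2 `COc1ccc(-c2cccc(NC(=O)CCc3cccc4c3B(O)OC4)c2)cc1`: 48 nM
- compound 3 `COc1cc(OC)cc(-c2cccc(NC(=O)CCc3cccc4c3B(O)OC4)c2)c1`: 44 nM

In this assay, compound 3 at 44 nM sits at the low end of the numbers together with compound 2, with a 1.1-fold lower number from compound 2 to compound 3 (0.04 log units; within the scatter). Compound 1 lies well apart, with a 22-fold lower number from compound 1 to compound 3 (1.35 log units; beyond the scatter).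

Compound 4 `COc1cc(OC)cc(-c2cccc(NC(=O)CCc3cccc4c3COB4O)c2)c1` has the same atoms as compound 3, joined differently. The change is a group of 10 heavy atoms (7 carbon, 1 boron, 2 oxygen; one five-membered non-aromatic ring with 2 hetero atoms, one six-membered aromatic ring of carbon only) in place of a group of 10 heavy atoms (7 carbon, 1 boron, 2 oxygen; one five-membered non-aromatic ring with 2 hetero atoms, one six-membered aromatic ring of carbon only), on a saturated chain carbon, two bonds along the chain from a carbonyl carbon. The chain and the far aryl end stay the same, and only the way the bicyclic group is joined to the saturated chain carbon differs.

For the measured compounds named here, no measured step alters that group, so none speaks to this change directly. The nearest evidence comes from the other end of the molecule. There, a 20-fold lower number from compound 1 to compound 2 (1.31 log units; beyond the scatter) and a 22-fold lower number from compound 1 to compound 3 (1.35 log units; beyond the scatter) show that a single change can move this series a long way, while a 1.1-fold lower number from compound 2 to compound 3 (0.04 log units; within the scatter) shows that another can leave it unmoved. A large step towards a higher number is expected, though with wide uncertainty, since all three measured compounds keep the core of compound 3. The expected change is a 20-fold higher number from compound 3 to compound 4 (1.31 log units; beyond the scatter). For compound 4 the estimate is 900 nM, with an expected range from 150 nM to 6000 nM.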

Compound 4, half-maximal inhibitory concentration: 88000 nM
The estimate for compound 4 lay 98-fold (1.99 log units) below the measured number; the whole stated range lies below it.
By their numbers in this assay, from the lowest: compounds 3 and 2 (each within the scatter of the next); then compound 1; then compound 4.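

In this assay, for the compounds shown here, the step of a 2000-fold higher number from compound 3 to compound 4 (3.30 log units; beyond the scatter) is the first to touch the group on a saturated chain carbon, two bonds along the chain from a carbonyl carbon, and it shows that this position is far from indifferent. The same atoms, joined differently, with the chain and the far aryl end unchanged, move the number further than the change at the far aryl end, where the step of a 22-fold lower number from compound 1 to compound 3 (1.35 log units; beyond the scatter) had been the largest seen so far. The earlier compounds all kept one arrangement of this group and so spoke only to the far aryl end, and nothing given here accounts for the effect of the new arrangement.

The compounds shown leave open whether the same rejoining would cost as much with the 4-methoxyphenyl or ethynyl ends, since it is seen only with the 3,5-dimethoxyphenyl end. They also leave open what a carboxylic acid or an amine would do on this saturated chain carbon in place of the bicyclic group, and so whether the boron-bearing ring is needed at all.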